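This account rests on a few compounds, and the source may have more. Where it says the series, first, only, none or still open, it means among the compounds named here.

Measured so far:
Compound 1 `O=C1/C(=C/c2ccc(F)cc2)Cc2cc(O)ccc21` gives 47 nM in an assay on isolated protein for inhibition of Amine oxidase [flavin-containing] B (Homo sapiens), read by fluorescence and spectrophotometry, with a stated time of 20 min; a higher number here means a weaker inhibitor, a lower number a stronger inhibitor.
Compound 2 `N#Cc1ccc(/C=C2\Cc3cc(O)ccc3C2=O)cc1` gives 316 nM in this assay.
Compound 3 `O=C1/C(=C/c2ccc(Cl)c(Cl)c2)Cc2cc(O)ccc21` gives 14 nM in this assay.

Among these three, compound 2 has the highest number and is thus the weakest inhibitor of the set; compound 1 sits closest to it and compound 3 furthest away. Within the data shown here, only one measured step joins two compounds that differ in a single place: a 6.7-fold higher number from compound 1 to compound 2 (0.83 log units; beyond the scatter). Compound 4 `CC(C)c1ccc(/C=C2\Cc3cc(O)ccc3C2=O)cc1` is the next compound to be tested; it differs from compound 2 by isopropyl in place of cyano on an aromatic carbon. Among the measured compounds shown here, no measured compound carries an isopropyl group, so that one step is the only guide: it shows that putting cyano onto that aromatic carbon raised the number appreciably, and taking it away again would plausibly undo part of that rise. The expected direction in this assay is therefore downward, with a size roughly comparable to the earlier step, giving an estimated step of a 5.3-fold lower number from compound 2 to compound 4 (0.72 log units; beyond the scatter). Compound 4 is expected to give about 60 nM, with a range from 20 nM to 200 nM.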

Compound 4, half-maximal inhibitory concentration: 215 nM
Estimate against measurement, compound 4: 3.6-fold (0.55 log units) below, outside the stated range (above it).
By their numbers in this assay, from the lowest: compound 3; then compound 1; then compounds 4 and 2 (each within the scatter of the next).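

In this assay, isopropyl in place of cyano gives a 1.5-fold lower number from compound 2 to compound 4 (0.17 log units; within the scatter), so this position does not separate these two groups, even though cyano carries a hydrogen-bond acceptor and isopropyl carries none. Measured against fluoro, isopropyl gives a 4.6-fold higher number from compound 1 to compound 4 (0.66 log units; beyond the scatter) and cyano gives a 6.7-fold higher number from compound 1 to compound 2 (0.83 log units; beyond the scatter) so the rise in the number seen earlier is no longer tied to cyano alone, and two quite different groups now stand on the same side of fluoro. No supporting evidence is available to explain this result.

On these data alone, what remains open is how an amine, a carboxylic acid or a longer chain would behave on this aromatic carbon. It is also unclear whether a single chloro group here would match fluoro or the dichloro compound 3.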